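The source may hold more compounds than are shown below. What is called first, only, known or untested is meant among the compounds shown, and "the series" means these compounds.

Compounds measured so far:
compound 1, `N#Cc1ncc(-n2c(=O)n(Cc3ccccc3)c3ccccc32)cc1C(F)(F)F` — 5300 nM
compound 2, `N#CCn1c(=O)n(-c2ccc(C#N)c(C(F)(F)F)c2)c2ccccc21` — 18900 nM
compound 3, `N#Cc1ncc(-n2c(=O)n(Cc3ccccc3)c3cccnc32)cc1C(F)(F)F` — 1700 nM

In a physicochemical assay for solubility (on this read-out higher numbers stand for higher solubility and lower numbers for lower solubility), compound 2 gives the highest of the three numbers. Compound 1 sits beyond the scatter below it, and compound 3 sits further still below it, also beyond the scatter. No two of these three compounds differ in only one place, so the numbers show where each stands but not what any single change does.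

Compound 4, `N#Cc1ccc(-n2c(=O)n(Cc3ccccn3)c3ccccc32)cc1C(F)(F)F`, has not yet been measured in this assay. It differs from compound 2 by pyridin-2-yl in place of cyano on a saturated chain carbon bound to an aromatic nitrogen; cut one bond further out, the change reads cyanomethyl to (pyridin-2-yl)methyl. Compound 1, which carries a benzyl group in this place, gives 5300 nM, a lower number than compound 2, although its core also differs from that of compound 2. On that basis compound 4 is expected to fall below compound 2 by a step of a 2.4-fold lower number from compound 2 to compound 4 (0.37 log units; beyond the scatter), beyond the scatter. The estimate for compound 4 is 8000 nM, with a range from 3000 nM to 20000 nM.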

Compound 4, solubility: 12000 nM
For compound 4 the middle estimate is 1.5-fold (0.18 log units) below the measured one, and the stated range covers the measured number.
By their numbers in this assay, from the lowest: compound 3; then compound 1; then compounds 4 and 2 (each within the scatter of the next).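

Among these compounds, this is the first reading at this place on a single core: pyridin-2-yl in place of cyano on the saturated chain carbon bound to an aromatic nitrogen gives (a 1.6-fold lower number from compound 2 to compound 4 (0.20 log units; within the scatter)) in this assay. Although the entering group has 6 heavy atoms and an aromatic ring while the leaving group has 2 heavy atoms and no ring, compounds 2 and 4 cannot be told apart on this read-out. Nothing measured here bears on why the two groups read alike.

The compounds shown leave open whether this tolerance extends beyond these two groups, since a carboxylic acid or an amine on the same chain carbon could give a different result. They also leave open whether a pyridin-2-yl group would read the same way on the other cores shown.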